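The compounds below may be only part of what the source reports. "The series", "measured", "known", "first", "only" and "open" are said of these compounds alone.

In a functional assay on HepG2 cells (Homo sapiens) for inhibition, read by MTT assay (on this read-out lower numbers stand for stronger inhibition and higher numbers for weaker inhibition), three amides sharing one core have been measured. Compound 1 `COc1cc2ncnc(Nc3ccc(NC(=O)c4ccc(C(C)(C)C)cc4)cc3)c2cc1OC` gives > 100000 nM, which is a limit of the assay and not a number. Compound 2 `COc1cc2ncnc(Nc3ccc(NC(=O)c4ccccc4F)cc3)c2cc1OC` reads 13000 nM and compound 3 `COc1cc2ncnc(Nc3ccc(NC(=O)c4cccc(F)c4)cc3)c2cc1OC` reads 8200 nM. Going by the values given here, the change between these two is a 1.6-fold lower number from compound 2 to compound 3 (0.20 log units; within the scatter), which lies within the scatter, so compound 3 stands level with compound 2, and they hold the only two true numbers available.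

Compound 4 `COc1cc2ncnc(Nc3ccc(NC(=O)c4ccc(Cl)cc4)cc3)c2cc1OC` carries 4-chlorophenyl in place of 3-fluorophenyl on a carbonyl carbon. Only steps at this same carbonyl carbon bear on the change. Going by these compounds, two of them are large enough to matter, an at least 7.6-fold lower number from compound 1 to compound 2 (0.88 log units; beyond the scatter) and an at least 12-fold lower number from compound 1 to compound 3 (1.08 log units; beyond the scatter), both beyond the scatter, and each starts from a limit, so its full size remains open. Among the compounds with values here, the aryl group on the carbonyl can therefore shift the number considerably, yet no chlorophenyl compound has been measured. Compound 4 is expected to fall between the fluorophenyl pair and compound 1, closer to the pair, with a weaker reading than compound 3 in this assay. The expected change is modest, an estimated 2.4-fold higher number from compound 3 to compound 4 (0.39 log units; beyond the scatter). The estimate for compound 4 is 20000 nM, with an expected range from 6000 nM to 70000 nM.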

Compound 4, half-maximal inhibitory concentration: 28000 nM
Compound 4: middle estimate off by 1.4-fold (0.15 log units), on the low side, and the stated range covers the measured number.
By their numbers in this assay, from the lowest: compounds 3 and 2 (each within the scatter of the next); then compound 4. At a limit, above all of these: compound 1.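

In this assay, compound 4 shows that the aryl group on this carbonyl carbon can separate compounds that each carry a single halogen: there is a 3.4-fold higher number from compound 3 to compound 4 (0.53 log units; beyond the scatter) and a 2.2-fold higher number from compound 2 to compound 4 (0.33 log units; beyond the scatter), whereas the two fluorophenyl compounds stand level within the scatter. The change from tert-butyl to chloro on an aromatic carbon gives an at least 3.5-fold lower number from compound 1 to compound 4 (0.55 log units; beyond the scatter), which places compound 4 in a true reading of its own, at higher numbers than the fluorophenyl pair and at lower numbers than the limit of compound 1. The full size of that step remains open, as compound 1 gives a limit and not a number: the limit of > 100000 nM in this assay, at which 1 of the 4 values shown sits.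

Going from 3-fluorophenyl to 4-chlorophenyl changes both the halogen and the printed ring number, and the compounds shown cannot separate these two changes, a question that 3-chlorophenyl or 4-fluorophenyl on the same carbonyl carbon would address. Going by these compounds, it also remains open how an amine, a carboxylic acid or a nitrile on this aromatic ring would read in this assay.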